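Sulfonamide variants on the shared core: aryl chlorine position

This account rests on a few compounds, and the source may have more. Where it says the series, first, only, none or still open, it means among the compounds named here.

Four compounds share one core and differ only in the sulfonamide part. Compound 1 `CN(c1ccccc1Cl)S(=O)(=O)C1CC2OC1C(c1ccc(NC(=O)CCCCCCC(=O)O)cc1)=C2c1ccc(O)cc1` and compound 2 `CN(c1ccc(Cl)cc1)S(=O)(=O)C1CC2OC1C(c1ccc(NC(=O)CCCCCCC(=O)O)cc1)=C2c1ccc(O)cc1` carry a methyl on the sulfonamide nitrogen; compound 3 `CCN(c1ccccc1Cl)S(=O)(=O)C1CC2OC1C(c1ccc(NC(=O)CCCCCCC(=O)O)cc1)=C2c1ccc(O)cc1` and compound 4 `CCN(c1ccc(Cl)cc1)S(=O)(=O)C1CC2OC1C(c1ccc(NC(=O)CCCCCCC(=O)O)cc1)=C2c1ccc(O)cc1` carry an ethyl there. In a functional assay on DU-145 cells (Homo sapiens) for antiproliferative activity, read by MTT assay, with a stated time of 72 h (on this read-out lower numbers stand for stronger inhibition and higher numbers for weaker inhibition), compound 1 gives 73500 nM. In this assay compound 2 gives 72100 nM. For compound 3 this assay reports only a limit, > 100000 nM, which is the limit of > 100000 nM in this assay, at which 1 of the 3 values shown sits.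

The change from compound 1 to compound 2 is 4-chlorophenyl in place of 2-chlorophenyl on a sulfonamide nitrogen, and it gave a 1.0-fold lower number from compound 1 to compound 2 (0.01 log units; within the scatter). The cores of compound 3 and compound 4 differ from those of compound 1 and compound 2 by methyl in place of hydrogen on a saturated chain carbon bound to a sulfonamide nitrogen, which gave an at least 1.3-fold higher number from compound 1 to compound 3 (0.13 log units; that floor lies within the scatter) and, from the other side, an at least 1.3-fold higher number from compound 2 to compound 3 (0.14 log units; that floor lies within the scatter). The change from compound 3 to compound 4 is 4-chlorophenyl in place of 2-chlorophenyl on a sulfonamide nitrogen, the same change as before, at the same place.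

Since that change gave a 1.0-fold lower number from compound 1 to compound 2 (0.01 log units; within the scatter), compound 4 is expected to sit close to compound 3, with a step that the limit leaves unreadable from compound 3 to compound 4. For compound 4 the estimate in this assay is 130000 nM, between 70000 nM and 300000 nM, and most likely again a limit.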

Compound 4, half-maximal inhibitory concentration: 42100 nM
Estimate against measurement, compound 4: 3.1-fold (0.49 log units) above; measured number below the stated range.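

Placing 4-chlorophenyl in place of 2-chlorophenyl on the sulfonamide nitrogen of the ethyl compounds gave a step beyond the scatter, an at least 2.3-fold lower number from compound 3 to compound 4 (0.37 log units; beyond the scatter), and beside the methyl pair this reads: the same change on two cores in this assay, a 1.0-fold lower number (0.01 log units; within the scatter) from compound 1 to compound 2 and an at least 2.3-fold lower number (0.37 log units; beyond the scatter) from compound 3 to compound 4; the limit leaves it open whether they differ. Compound 3 has only a limit, > 100000 nM, so the pair shows that the change can be read on the ethyl core but does not show that it behaves differently on the two cores. With the 4-chlorophenyl held, ethyl against methyl gives a 1.7-fold lower number from compound 2 to compound 4 (0.23 log units; within the scatter), the step that alters both places gives a 1.7-fold lower number from compound 1 to compound 4 (0.24 log units; within the scatter), both lie within the scatter, and the ethyl change on its two cores reads: the same change on two cores in this assay, an at least 1.3-fold higher number (0.13 log units; that floor lies within the scatter) from compound 1 to compound 3 and a 1.7-fold lower number (0.23 log units; within the scatter) from compound 2 to compound 4; the limit leaves it open whether they differ.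

As far as these compounds go, how a phenyl without chlorine, a 3-chlorophenyl or a propyl on the sulfonamide nitrogen would read in this assay remains open. Also open, from the compounds shown here alone, is whether a number for compound 3 in place of its limit would separate the two chlorine steps.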